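This account rests on a few compounds, and the source may have more. Where it says the series, first, only, none or still open, it means among the compounds named here.

Working notes on the series. Compound 1 `COc1ccc([C@H]2CC(=O)N(Cc3cccc(C#N)c3)C2)cc1OC1CCCC1` and compound 2 `COc1ccc([C@H]2CC(=O)N(c3cccc(NCc4ccoc4)c3)C2)cc1OC1CCCC1` share a common core, and compound 3 `COc1ccc([C@H]2CC(=O)N(c3cccc(NS(=O)(=O)c4ccccc4Br)c3)C2)cc1OC1CCCC1` is the next member awaiting a result. In a functional assay on HEK293 cells (Homo sapiens) for cytotoxicity (on this read-out lower numbers stand for higher toxicity in this test and higher numbers for lower toxicity in this test), compound 1 gives > 10000 nM, which is a limit of the assay rather than a number. In this assay compound 2 gives > 10000 nM, again a limit of the assay and not a number. For the measured compounds named here, compound 2 thus sits at the same limit as compound 1 (the limit of > 10000 nM in this assay, at which 2 of the 2 values shown sit); with two limits and no numbers, no step between the measured compounds can be stated, and their two values show no difference. From compound 2 to compound 3 the change is (2-bromophenyl)sulfonyl in place of (furan-3-yl)methyl on a nitrogen on an aromatic ring. Going by the values given here, nothing among the measured compounds resembles this change, so the expected step that the limit leaves unreadable from compound 2 to compound 3 is none beyond the scatter. Compound 3 is accordingly estimated at 15000 nM, within a range from 7000 nM to 40000 nM.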

Compound 3, half-maximal cytotoxic concentration: > 10000 nM
Compound 3: no number, only a limit; the forecaster's own chance of this, stated with the estimate: 80%; the middle value does not contradict the limit.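

No new step can be read from compound 2 to compound 3 in this assay, as each gives only a limit of the assay: the limit of > 10000 nM in this assay, at which 3 of the 3 values shown sit.

The compounds shown leave open whether (2-bromophenyl)sulfonyl and (furan-3-yl)methyl on that nitrogen differ at all on this read-out, since none of the three yields a number.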